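The source may report more compounds than this note shows. Statements on the series, on what has been measured and on what is new or still open speak of the compounds shown alone.

In a functional assay on KB cells (Homo sapiens) for antiproliferative activity, read by sulforhodamine B assay, with a stated time of 3 days (on this read-out higher numbers stand for an effect only at larger amounts of compound and lower numbers for an effect already at smaller amounts), compound 1 `CCC1=C(O)c2c(oc(-c3ccc(OC)cc3)cc2=O)C(CC)(CC)C1=O` gives 17.7 uM and compound 2 `CCC1=C(O)c2c(oc(-c3cc(C)c(O)c(C)c3)cc2=O)C(CC)(CC)C1=O` gives 18.3 uM, so the two stand within the scatter of each other. Compound 3 `CCC1=C(O)c2c(oc(-c3cccc(C)c3C)cc2=O)C(CC)(CC)C1=O` follows from compound 2 by this change: 2,3-dimethylphenyl in place of 4-hydroxy-3,5-dimethylphenyl on an aromatic carbon. Within the data shown here, the only measured step at this place, a 1.0-fold higher number from compound 1 to compound 2 (0.01 log units; within the scatter), stayed within the scatter, so no step beyond the scatter is expected in this assay. Among the measured compounds shown here, no measured compound carries 2,3-dimethylphenyl, so the range is kept wide. The expected step is a 1.0-fold lower number from compound 2 to compound 3 (0.01 log units; within the scatter). For compound 3 the estimated value is 18 uM, with an expected range of 8 uM to 38 uM.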

Compound 3, concentration for half-maximal effect: 3.1 uM
Compound 3: the middle estimate sits 5.8-fold (0.76 log units) above what was measured, outside the stated range (below it).
By their numbers in this assay, from the lowest: compound 3; then compounds 1 and 2 (each within the scatter of the next).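

Aryl changes on the shared core are not all silent in this assay: 2,3-dimethylphenyl gives a 5.9-fold lower number from compound 2 to compound 3 (0.77 log units; beyond the scatter) and a 5.7-fold lower number from compound 1 to compound 3 (0.76 log units; beyond the scatter), whereas a 1.0-fold higher number from compound 1 to compound 2 (0.01 log units; within the scatter) stayed within the scatter. Compared with 4-hydroxy-3,5-dimethylphenyl, the entering group has no hydroxy group and a different methyl pattern, and this single step cannot separate those two differences.

Still open, on these data alone, is how plain phenyl, aminophenyl or carboxyphenyl would compare with 2,3-dimethylphenyl. No supporting data are available to account for the lower number with 2,3-dimethylphenyl.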